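Quinoline thiosemicarbazones: halophenyl variation and HT-29 antiproliferation

This account rests on a few compounds, and the source may have more. Where it says the series, first, only, none or still open, it means among the compounds named here.

Of the compounds shown here, three sharing a quinoline-derived thiosemicarbazone core have been tested in a functional assay on HT-29 cells (Homo sapiens) for antiproliferative activity, read by sulforhodamine B assay, with a stated time of 72 h; on this read-out higher numbers stand for weaker inhibition and lower numbers for stronger inhibition. Compound 1 `Fc1ccccc1NC(=S)N/N=C/c1ccc2ccccc2n1` carries a 2-fluorophenyl group on the amide-type nitrogen; in this assay compound 1 reaches only the limit > 100000 nM, which is a limit of the measurement and not a number. Compound 2 `S=C(N/N=C/c1ccc2ccccc2n1)Nc1ccccc1Br` carries a 2-bromophenyl group there; in this assay compound 2 likewise stops at the limit > 100000 nM. Going by the values given here, compound 3 `S=C(N/N=C/c1ccc2ccccc2n1)Nc1ccc(Br)cc1` carries a 4-bromophenyl group and in this assay compound 3 gives 54400 nM, the only number among the three. Compound 3 and compound 2 have the same atoms joined differently: 4-bromophenyl in place of 2-bromophenyl on an amide-type nitrogen. The resulting step is an at least 1.8-fold lower number from compound 2 to compound 3 (0.26 log units; that floor lies within the scatter), and the corresponding step of an at least 1.8-fold lower number from compound 1 to compound 3 (0.26 log units; that floor lies within the scatter) is of the same size; both rest on (the limit of > 100000 nM in this assay, at which 2 of the 3 values shown sit), at which two of the three values sit.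

The change of interest is fluoro in place of bromo on an aromatic carbon. Made once between measured compounds, it reads fluoro in place of bromo on an aromatic carbon and gives a step that the two limits leave unreadable from compound 2 to compound 1. The untested compound 4 `Fc1ccc(NC(=S)N/N=C/c2ccc3ccccc3n2)cc1` arises from compound 3 by the same kind of change, (fluoro in place of bromo on an aromatic carbon); the surroundings differ, the earlier change sitting ortho to a large group and this one para to a large group. Because a step that the two limits leave unreadable from compound 2 to compound 1 is unreadable, the step is expected to be a 1.5-fold higher number from compound 3 to compound 4 (0.17 log units; within the scatter), taking compound 3 at 54400 nM as the only anchor. For compound 4 the estimated value is 80000 nM, with an expected range from 30000 nM to 200000 nM.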

Compound 4, half-maximal inhibitory concentration: 28500 nM
The estimate for compound 4 lay 2.8-fold (0.45 log units) above the measured number, and the stated range ends above it.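

In this assay, the one readable case of fluoro in place of bromo on an aromatic carbon, para to a large group, is a 1.9-fold lower number from compound 3 to compound 4 (0.28 log units; within the scatter), which lies within the scatter and so does not separate the 4-bromophenyl and 4-fluorophenyl compounds. The same exchange between the 2-bromophenyl and 2-fluorophenyl compounds cannot be read, so these data do not show whether the exchange behaves alike in the two surroundings, and the other unreadable steps rest on the same limit: the limit of > 100000 nM in this assay, at which 2 of the 4 values shown sit.
The steps beyond the scatter involve the 4-fluorophenyl group replacing a 2-halophenyl group, with the halogen kept in an at least 3.5-fold lower number from compound 1 to compound 4 (0.54 log units; beyond the scatter) and exchanged as well in an at least 3.5-fold lower number from compound 2 to compound 4 (0.54 log units; beyond the scatter); both are floors and not full sizes, and compound 3 goes against any general reading, since its steps from the same two compounds have floors within the scatter.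

Open, on these data alone, is whether a chloro or methoxy group in place of the bromo, or an amine or a carboxylic acid on the same aromatic ring, would fit alongside compound 3 and compound 4. As far as these compounds go, all four compounds share one core, so the outcome of this exchange on any other core also stays open.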